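Moving a Methyl on the Pyridine Ether and Solubility

A few compounds are considered here, and "the series" means these few. Any claim that something is new, unique, unknown or untested is made for them only; others in the source may bear on it.

Compound 1 `Cc1ccnc(Oc2ccc3nc(COc4cccc(C(=O)O)c4)n(C)c3c2)c1`: 33 ug/mL
Compound 2 `Cc1ccc(Oc2ccc3nc(COc4cccc(C(=O)O)c4)n(C)c3c2)nc1C`: 190 ug/mL

For the measured compounds named here, in a physicochemical assay for solubility, read by HPLC, measured as thermodynamic solubility, with a stated time of 4 h, at pH 6.8 (a lower number here means a less soluble compound, a higher number a more soluble compound), compound 2 gives 190 ug/mL, the highest of the two numbers measured so far, while compound 1 gives 33 ug/mL. Going by the values given here, the one measured step, a 5.8-fold higher number from compound 1 to compound 2 (0.76 log units; beyond the scatter), came from changing which methyl groups sit on the pyridine ring attached through the ether oxygen. Compound 3 `Cc1ccc(C)c(Oc2ccc3nc(COc4cccc(C(=O)O)c4)n(C)c3c2)n1` differs from compound 2 in that same ring: 3,6-dimethylpyridin-2-yl in place of 5,6-dimethylpyridin-2-yl on an oxygen on an aromatic ring. Among the compounds with values here, only the step from compound 1 to compound 2 bears on this, and it shows that rearranging methyls on this ring can shift this assay beyond the scatter. It gives no guidance on direction for this particular rearrangement, so a step of modest size either way is plausible. Compound 3 is therefore expected to fall near 120 ug/mL in this assay, with a range from 35 ug/mL to 350 ug/mL. This estimate corresponds to an expected step of a 1.6-fold lower number from compound 2 to compound 3 (0.20 log units; within the scatter).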

Compound 3, solubility: 85 ug/mL
The estimate for compound 3 lay 1.4-fold (0.15 log units) above the measured number; measured number inside the range.
By their numbers in this assay, from the lowest: compound 1; then compound 3; then compound 2.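

Exchanging 5,6-dimethylpyridin-2-yl for 3,6-dimethylpyridin-2-yl keeps the same atoms but joins them differently, and it gives a 2.2-fold lower number from compound 2 to compound 3 (0.35 log units; beyond the scatter) in this assay. So on this ring attached through the ether oxygen, where the two methyl groups stand makes a difference to the number, not just the fact that two are present. Compared with the single methyl of 4-methylpyridin-2-yl, the 3,6-dimethylpyridin-2-yl group still gives a 2.6-fold higher number from compound 1 to compound 3 (0.41 log units; beyond the scatter), so both dimethyl compounds shown read higher than compound 1, although no measurement here explains these differences.

The compounds shown leave open what a methoxy group or an amine on this ring would do in place of a methyl group. They also leave open whether a longer chain, such as an ethyl group, would follow the same order.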